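Carbonyl substituent swap from compound 2 to compound 4

This account rests on a few compounds, and the source may have more. Where it says the series, first, only, none or still open, it means among the compounds named here.

Compound 2 `COc1ccc(-c2cnc3nc(N)nc(N4CCN(C(=O)COc5ccccc5)CC4)c3n2)cc1OC` holds the lowest number of the three measured in a functional assay on cells (T-cell, Homo sapiens) for inhibition; a lower number here means a stronger inhibitor, a higher number a weaker inhibitor: compound 2 gives 4 nM, compound 3 `COc1ccc(-c2cnc3nc(N)nc(NC4CCCC4)c3n2)cc1OC` gives 800 nM, and compound 1 `COc1ccc(-c2cnc3nc(N)nc(NCc4ccccc4)c3n2)cc1OC` gives 13000 nM. The gaps from compound 2 to compound 3 and to compound 1 both lie beyond the scatter. Among the compounds with values here, the single step measured between close neighbours, a 16-fold lower number from compound 1 to compound 3 (1.21 log units; beyond the scatter), concerns the group on the ring nitrogen and not the carbonyl end, so it does not bear directly on the change at hand. Compound 4 `COc1ccc(-c2cnc3nc(N)nc(N4CCN(C(=O)NCc5ccccc5)CC4)c3n2)cc1OC` differs from compound 2 only at the carbonyl carbon: benzylamino in place of phenoxymethyl on a carbonyl carbon. Within the data shown here, no measured pair probes this position; both groups carry one six-membered aromatic ring of carbon only, and one hydrogen-bond donor enters where one hydrogen-bond acceptor leaves. The expectation for compound 4 in this assay is therefore a step of a 2.0-fold higher number from compound 2 to compound 4 (0.30 log units; within the scatter), most likely within the scatter or a modest weakening. Compound 4 is estimated at 8 nM, with a range from 2 nM to 30 nM.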

Compound 4, half-maximal inhibitory concentration: 18 nM
For compound 4 the middle estimate is 2.3-fold (0.35 log units) below the measured one, and the stated range covers the measured number.
By their numbers in this assay, from the lowest: compound 2; then compound 4; then compound 3; then compound 1.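

Within the data shown here, this is the only measured pair at the carbonyl end of the series: in this assay the swap gives a 4.5-fold higher number from compound 2 to compound 4 (0.65 log units; beyond the scatter) and so lies beyond the scatter, a modest loss and not a collapse. The aromatic ring and the heavy-atom count stay the same, so exchanging the hydrogen-bond acceptor of phenoxymethyl for the hydrogen-bond donor of benzylamino on this carbonyl carbon is enough to move the number, while compound 4 still reads 18 nM in the low nanomolar range. Nothing at hand says why the number moves.

Open, as far as these compounds go, is whether the step follows the donor that enters, the acceptor that leaves, or both; a phenethyl chain on the carbonyl carbon would carry neither. Also open, from the compounds shown here alone, is how a shorter anilino group would read at this position.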